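A Terminal Hydroxy in Place of the Vinyl Group

The compounds below may be only part of what the source reports. "The series", "measured", "known", "first", "only" and "open" are said of these compounds alone.

Of the compounds shown here, three sharing one core have been measured in an assay on isolated protein for binding affinity to leukotriene B4 receptor 1 (Homo sapiens), tested at 1 uM; on this read-out higher numbers stand for more inhibition at the one concentration tested (going by the name of the read-out) and lower numbers for less inhibition. Compound 1 `C=CCc1cc(C(C)=O)c(O)cc1OCCCCC#N` gives 57%, compound 2 `C=CCc1cc(C(C)=O)c(O)cc1OCCCCCCC#N` gives 63%, and compound 3 `C=CCCCCOc1cc(O)c(C(C)=O)cc1CC=C` gives 27%. Compound 3 thus stands lowest of the three: the step of a number 30 percentage points lower from compound 1 to compound 3 (beyond the scatter) and the step of a number 36 percentage points lower from compound 2 to compound 3 (beyond the scatter) both fall beyond the scatter, while the step of a number 6 percentage points higher from compound 1 to compound 2 (within the scatter) does not.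

Compound 4 `C=CCc1cc(C(C)=O)c(O)cc1OCCCCO` is not yet measured. It differs from compound 3 by hydroxy in place of vinyl on a saturated chain carbon, four bonds along the chain from an oxygen on an aromatic ring. No measured step involves a hydroxy group, so the bearing of the shown steps is indirect. What they do show is that the vinyl terminus sits behind the two weaker results, and that a terminus carrying a heteroatom, as in compound 1 and compound 2, goes with the higher numbers. The entering hydroxy brings one hydrogen-bond donor and one hydrogen-bond acceptor where the vinyl brought none, which is the most that can be said from the structures alone.

On that basis compound 4 is expected to give 45% in this assay, within 20% to 70%, meaning an expected step of a number 18 percentage points higher from compound 3 to compound 4 (beyond the scatter), modest and upward rather than beyond doubt.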

Compound 4, a percentage reported as inhibition, at one concentration (the size of the read-out at that concentration, not a potency): 9%
Estimate against measurement, compound 4: 36 percentage points above; the whole stated range lies above it.
By their numbers in this assay, from the lowest: compound 4; then compound 3; then compounds 1 and 2 (each within the scatter of the next).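

In this assay, the hydroxy terminus does not improve on the vinyl group but falls short of it, with a number 18 percentage points lower from compound 3 to compound 4 (beyond the scatter), so the presence of a heteroatom at the chain end does not by itself go with the higher numbers. The gap to the nitrile-ended chains is wider still, with a number 48 percentage points lower from compound 1 to compound 4 (beyond the scatter) and a number 54 percentage points lower from compound 2 to compound 4 (beyond the scatter), which shows that this place on a saturated chain carbon, four bonds along the chain from an oxygen on an aromatic ring, distinguishes sharply among terminal groups. Of the four termini, the nitrile-ended chains alone reach the higher numbers, and the hydroxy, which brings a hydrogen-bond donor and a hydrogen-bond acceptor, goes with the lowest. Nothing accompanying these numbers explains why the hydroxy compound gives so little inhibition.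

On these data alone, whether an amine, a carboxylic acid or a methyl ether at the chain end would stand nearer compound 4 or nearer compound 1 remains open. Also open, as far as these compounds go, is whether a longer chain carrying the same hydroxy would recover any of the inhibition.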